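This account rests on a few compounds, and the source may have more. Where it says the series, first, only, none or still open, it means among the compounds named here.

The shared core of these compounds carries a propanamide linking a fluorinated methanesulfonamide-bearing ring to a trifluoromethyl-substituted benzylamine, and the compounds differ only in the group on that benzyl ring. In an assay on CHO cells for antagonist activity at transient receptor potential cation channel subfamily V member 1 (Homo sapiens), read by FLIPR (a lower number here means a stronger inhibitor, a higher number a weaker inhibitor), compound 1 `CCCCN(C)c1cc(C(F)(F)F)ccc1CNC(=O)C(C)c1ccc(NS(C)(=O)=O)c(F)c1` gives 1.2 nM, and compound 2 `CC(C(=O)NCc1ccc(C(F)(F)F)cc1N1CCCCCCC1)c1ccc(NS(C)(=O)=O)c(F)c1` gives 2.8 nM; the step of a 2.3-fold higher number from compound 1 to compound 2 (0.37 log units; beyond the scatter) shows that swapping one amine-type substituent for another changes the result only modestly. Compound 3 `CC(C(=O)NCc1ccc(C(F)(F)F)cc1SCCCO)c1ccc(NS(C)(=O)=O)c(F)c1` is different: in this assay compound 3 is reported as "not active" (no number reported), and no number accompanies that report, so compound 3 stands outside the measured range of compounds 1 and 2.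

Compound 4 `CC(C(=O)NCc1ccc(C(F)(F)F)cc1Cl)c1ccc(NS(C)(=O)=O)c(F)c1` differs from compound 3 by chloro in place of (3-hydroxypropyl)sulfanyl on an aromatic carbon. Among the measured compounds shown here, no measured step involves a chloro group, so nothing in the data bears directly on this change; the only measured step, from compound 1 to compound 2, concerns a different position and is modest. Compound 4 is therefore expected to land at an estimated 10 nM, within a range of 2 nM to 60 nM.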

Compound 4, inhibition constant: 4 nM
Estimate against measurement, compound 4: 2.5-fold (0.40 log units) above; the measured number falls inside the stated range.
By their numbers in this assay, from the lowest: compound 1; then compounds 2 and 4 (each within the scatter of the next).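

Chloro keeps a measurable number in this assay where (3-hydroxypropyl)sulfanyl does not: compound 3 is reported as "not active" (no number reported) and so the change to compound 4 cannot be sized as a step. Replacing the eight-membered ring with chlorine gives a 1.4-fold higher number from compound 2 to compound 4 (0.15 log units; within the scatter) and replacing butyl(methyl)amino with chloro gives a 3.3-fold higher number from compound 1 to compound 4 (0.52 log units; beyond the scatter) so on this aromatic carbon a nitrogen group is not required for a low number, with compound 3 the only one of the four that goes against this. No measurement shown explains why compound 3 stands apart.

Still open, on these data alone, is whether the sulfur or the hydroxyl goes with the "not active" report, which a butylsulfanyl chain or a 3-hydroxypropylamino group would help separate. Also open, as far as these compounds go, is how fluorine or plain hydrogen on this carbon would read.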